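This account rests on a few compounds, and the source may have more. Where it says the series, first, only, none or still open, it means among the compounds named here.

Three close relatives share one core and differ only in the aryl group sitting on a double-bonded chain carbon bound to a double-bonded ring carbon. Compound 1 `COc1cccc(/C=C2\CCC/C(=C\c3cccc(Cl)c3)C2=O)c1OC` gives 10300 nM in a functional assay on HT-1080 cells (Homo sapiens) for cytotoxicity, read by MTT assay, with a stated time of 72 h; on this read-out lower numbers stand for stronger inhibition and higher numbers for weaker inhibition. Compound 2 `COc1cccc(/C=C2\CCC/C(=C\c3ccccc3Br)C2=O)c1OC` gives 10800 nM in this assay, and compound 3 `COc1cccc(/C=C2\CCC/C(=C\c3ccc(Cl)c(Cl)c3)C2=O)c1OC` gives 10800 nM. Compound 2 thus stands level with compound 3 at the digits shown, the two together the highest of the three numbers, with compound 1 as its furthest neighbour: a 1.0-fold higher number from compound 1 to compound 2 (0.02 log units; within the scatter). The other steps are just as flat: a 1.0-fold higher number from compound 1 to compound 3 (0.02 log units; within the scatter) and no change at the digits printed from compound 2 to compound 3 (within the scatter). Compound 4 `COc1cccc(/C=C2\CCC/C(=C\c3ccc(O)c(O)c3)C2=O)c1OC` has not yet been measured; it differs from compound 2 as follows.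

3,4-dihydroxyphenyl in place of 2-bromophenyl on a double-bonded chain carbon bound to a double-bonded ring carbon

None of the three measured steps swaps a halogen-bearing ring for one carrying hydroxyls, so they bear on this change only loosely. What they do show is that moving or adding halogens on that ring left the number unchanged. From that flatness the expected step is a 1.1-fold higher number from compound 2 to compound 4 (0.05 log units; within the scatter), with no direction beyond the scatter. Among the measured compounds shown here, the uncertainty is wide, since no measured compound carries a hydroxyl. The estimate for compound 4 is therefore 12000 nM, expected to lie between 4000 nM and 40000 nM.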

Compound 4, half-maximal inhibitory concentration: 4700 nM
For compound 4 the middle estimate is 2.6-fold (0.41 log units) above the measured one; low and high end bracket the measured number.
By their numbers in this assay, from the lowest: compound 4; then compounds 1, 2 and 3 (each within the scatter of the next).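

Until now, this position had not separated the halogen-bearing rings, but 3,4-dihydroxyphenyl moves the number beyond the scatter in this assay against all three of them: a 2.3-fold lower number from compound 2 to compound 4 (0.36 log units; beyond the scatter) and a 2.3-fold lower number from compound 3 to compound 4 (0.36 log units; beyond the scatter) and a 2.2-fold lower number from compound 1 to compound 4 (0.34 log units; beyond the scatter) are modest steps of similar size. So the aryl group on this double-bonded chain carbon can change the cytotoxicity read-out, even though the halogen changes among compound 1, compound 2 and compound 3 did not. The change also brings in 2 hydrogen-bond donors and 2 hydrogen-bond acceptors where 2-bromophenyl has none, but nothing shown links those counts to the lower number, and no measurement here explains the step.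

With only one hydroxyl-bearing ring shown, it remains open whether both hydroxyls are needed or whether a single one, as in 4-hydroxyphenyl, would give a similar number. Also open, going by these compounds, is how this position would respond to a ring carrying methoxy, an amine or a carboxylic acid, or to plain phenyl with no added group.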